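The source may report more compounds than this note shows. Statements on the series, on what has been measured and on what is new or still open speak of the compounds shown alone.

Cell-killing potency is compared here through a functional assay on RKO cells (Homo sapiens) for cytotoxicity, read by resazurin assay, with a stated time of 72 h; a higher number here means a weaker inhibitor, a lower number a stronger inhibitor. In this test compound 1 (`COc1ccc(Nc2nc(-n3ccnc3C)cs2)cc1`) gives 1600 nM, a real reading that can anchor comparisons. Compound 2 (`c1ccc(Nc2nc(-n3ccnc3)cs2)cc1`) gives > 100000 nM, which is a limit of the assay and not a number. Its true position is therefore unknown, and any step that starts from it has an open end.

Compound 3 (`COc1ccc(Nc2nc(-n3ccnc3)cs2)cc1`) differs from compound 2 in one place: methoxy in place of hydrogen on an aromatic carbon. In words, a methoxy stands in place of hydrogen on an aromatic carbon, para to a large group. Among the compounds with values here, no measured pair shows this change on its own, so its size has to be judged indirectly. Within the data shown here, compound 1 is the only measured compound with a methoxy, and it gives 1600 nM. On that basis, a large gain in this assay is expected, well beyond the scatter, although a reading that stays at the limit remains possible. The expected step of an at least 16-fold lower number from compound 2 to compound 3 (1.22 log units; beyond the scatter) points toward stronger inhibition. For compound 3 the estimate is 6000 nM, with an expected range from 1200 nM to 40000 nM.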

Compound 3, half-maximal inhibitory concentration: > 100000 nM
Compound 3: no number, only a limit (the forecaster's own chance of this, stated with the estimate: 15%); middle value at least 16-fold (1.22 log units) away from the limit.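

In this assay, the methoxy on an aromatic carbon, para to a large group, does not by itself lift a compound off the limit: compound 3 gives > 100000 nM, which is a limit of the assay and not a number. Within the data shown here, the one step that can be read is hydrogen in place of methyl on an aromatic carbon, which brings an at least 62-fold higher number from compound 1 to compound 3 (1.79 log units; beyond the scatter), so in this pair the methyl separates a real reading from a limit, and the methoxy alone does not supply that reading. The step for adding the methoxy cannot be read, because both compounds at either end of it sit at the same limit: the limit of > 100000 nM in this assay, at which 2 of the 3 values shown sit.

Among the compounds shown, the methyl appears only together with the methoxy, so whether the methoxy contributes anything once the methyl is present stays open. As far as these compounds go, it is also open how an ethyl in the place of the methyl, or an amine in the place of the methoxy, would read in this assay.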